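A Dimethoxyphenyl Hydrazone on a Shared Core

A few compounds are considered here, and "the series" means these few. Any claim that something is new, unique, unknown or untested is made for them only; others in the source may bear on it.

Compound 1 `Cn1c(=O)c(=O)n(C2CCCC2)c2nc(N/N=C/c3ccccc3)ncc21` carries a phenyl on the carbon with a double bond to nitrogen. In a functional assay on A549 cells (Homo sapiens) for antiproliferative activity, read by MTT assay (a higher number here means a weaker inhibitor, a lower number a stronger inhibitor), compound 1 gives > 100000 nM, which is a limit of the assay and not a number. Compound 2 `Cn1c(=O)c(=O)n(C2CCCC2)c2nc(N/N=C/c3ccc(Cl)cc3)ncc21` has chloro in place of hydrogen on an aromatic carbon, and in this assay compound 2 gives 6890 nM. That change brought an at least 14-fold lower number from compound 1 to compound 2 (1.16 log units; beyond the scatter). Compound 3 `Cn1c(=O)c(=O)n(C2CCCC2)c2nc(N/N=C/c3ccco3)ncc21` bears a furan-2-yl instead of the phenyl. In this assay compound 3 gives > 100000 nM, again a limit. Compound 1 thus stands at the limit of > 100000 nM in this assay, at which 2 of the 3 values shown sit; only compound 2 yields a readable number, and the exchange of 4-chlorophenyl for furan-2-yl is an at least 14-fold higher number from compound 2 to compound 3 (1.16 log units; beyond the scatter), while the exchange of phenyl for furan-2-yl is a step that the two limits leave unreadable from compound 1 to compound 3.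

Compound 4 `COc1ccc(/C=N/Nc2ncc3c(n2)n(C2CCCC2)c(=O)c(=O)n3C)c(OC)c1` is not yet measured. Its change from compound 1 is 2,4-dimethoxyphenyl in place of phenyl on a carbon with a double bond to nitrogen. Going by the values given here, the only measured step from compound 1 that ends in a number is the one to compound 2, which shows that a substituent on the phenyl can lower the number greatly, but two methoxy groups are not a chloro, and no measured step speaks to them. A modest lowering is therefore expected, the step from compound 1 to compound 4 being estimated as an at least 3.3-fold lower number from compound 1 to compound 4 (0.52 log units; beyond the scatter). In this assay compound 4 is expected to give about 30000 nM, within 5000 nM to 150000 nM.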

Compound 4, half-maximal inhibitory concentration: > 100000 nM
Compound 4 ended at the assay's limit; the forecaster's own chance of this, stated with the estimate: 45%; middle value at least 3.3-fold (0.52 log units) away from the limit.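

Going by these compounds alone, on the carbon with a double bond to nitrogen, putting substituents on the phenyl does not by itself give a readable number in this assay: compound 4 carries 2,4-dimethoxyphenyl, yet compound 2, with its 4-chlorophenyl, remains the only one of the four compounds with a value that is a true number. The exchange of 4-chlorophenyl for 2,4-dimethoxyphenyl gives an at least 14-fold higher number from compound 2 to compound 4 (1.16 log units; beyond the scatter), so the lowering seen with the chloro does not carry over to these two methoxy groups. The steps to compound 4 from compound 1 and from compound 3 join two limits and cannot be read, and the series now gathers at a single ceiling: the limit of > 100000 nM in this assay, at which 3 of the 4 values shown sit.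

As far as these compounds go, it remains open whether other groups in place of the chloro, such as a bromo, a nitrile or a trifluoromethyl, would also give a readable number, or whether the chloro stands alone. Within the data shown here, it is also unknown how a phenyl with a single methoxy group would behave, and with only one readable value, the size of any such effect on the shared core cannot yet be judged.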